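Amine variation at the thiocarbonyl carbon: compound 3

A few compounds are considered here, and "the series" means these few. Any claim that something is new, unique, unknown or untested is made for them only; others in the source may bear on it.

Measured compounds:
compound 1, `S=C(SCc1nc2ccccc2[nH]1)N1CCCCC1`: 1660 nM
compound 2, `CN(C)C(=S)SCc1nc2ccccc2[nH]1`: 2120 nM

Both values come from a functional assay on the whole organism for inhibition, with Cicer arietinum as the target, with a stated time of 7 days; on this read-out lower numbers stand for stronger inhibition and higher numbers for weaker inhibition. Going by the values given here, compound 2 gives the higher of the two numbers, but its only neighbour is compound 1, and a 1.3-fold higher number from compound 1 to compound 2 (0.11 log units; within the scatter) stays within the scatter, so the two compounds cannot be told apart on these data. That step, dimethylamino in place of piperidin-1-yl on the thiocarbonyl carbon, is the only one measured, and it bears directly on the present question, since it too exchanges the amine part on the thiocarbonyl carbon while the remainder of the structure is unchanged.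

Compound 3, `CCCCNC(=S)SCc1nc2ccccc2[nH]1`, has not yet been measured in this assay. It differs from compound 2 as follows: butylamino in place of dimethylamino on a thiocarbonyl carbon. Among the compounds with values here, with the single comparable step lying within the scatter, no step beyond the scatter is expected in this assay in either direction, and the estimate therefore sits close to compound 2.

Compound 3 is expected to give about 2000 nM in this assay, with an estimated range from 900 nM to 4500 nM. The step of a 1.1-fold lower number from compound 2 to compound 3 (0.03 log units; within the scatter) is the expected one and no more.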

Compound 3, half-maximal inhibitory concentration: 2110 nM
Compound 3: middle estimate off by 1.1-fold (0.02 log units), on the low side; low and high end bracket the measured number.
By their numbers in this assay, from the lowest: compounds 1, 3 and 2 (each within the scatter of the next).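

On this assay butylamino in place of dimethylamino gives a 1.0-fold lower number from compound 2 to compound 3 (0.00 log units; within the scatter) and butylamino in place of piperidin-1-yl gives a 1.3-fold higher number from compound 1 to compound 3 (0.10 log units; within the scatter) on the same read-out. Until now the position on the thiocarbonyl carbon rested on a single comparison; it now also includes butylamino, with 5 heavy atoms and 1 hydrogen-bond donor against 3 and 0 for dimethylamino, and neither difference separates the three compounds on these numbers. For these three amine parts, then, the change leaves the read-out within the scatter, and no measurement at hand bears on why they read alike.

Still open, from the compounds shown here alone, is whether this flat picture holds for amine parts of another kind on the thiocarbonyl carbon, such as morpholin-4-yl, benzylamino or a longer chain such as octylamino. Equally open, going by these compounds, is whether the read-out stays at this level when the thiocarbonyl itself gives way to a carbonyl, or when the shared core is changed.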